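Swapping the amide substituent on a shared core

This account rests on a few compounds, and the source may have more. Where it says the series, first, only, none or still open, it means among the compounds named here.

Within the data shown here, compound 2 `CC(=O)N1CCC(NC(=O)c2ccncc2Nc2cc(-c3ccc4ccn(C)c4c3)c3nccnc3c2)CC1` is the only compound here with a numerical reading: in an assay on lysate for inhibition of 6-phosphofructo-2-kinase/fructose-2,6-bisphosphatase 3 (Homo sapiens), with stated times of 0.5 min and 45 min (on this read-out lower numbers stand for stronger inhibition and higher numbers for weaker inhibition), compound 2 gives 31300 nM. Compound 1 `CN(C)C(=O)c1ccncc1Nc1cc(-c2ccc3ccn(C)c3c2)c2nccnc2c1` differs from it only in carrying a dimethylamino group on the carbonyl carbon. In this assay compound 1 reaches only the assay limit of > 100000 nM. Going by these compounds, the step from the small amide to the larger one is an at least 3.1-fold lower number from compound 1 to compound 2 (0.50 log units; beyond the scatter), and because of the limit of > 100000 nM in this assay, at which 1 of the 2 values shown sits, its exact size stays open. Compound 3 `Cn1ccc2ccc(-c3cc(Nc4cnccc4C(=O)NCC4COCCN4)cc4nccnc34)cc21` keeps the shared core of compound 2 and changes the amide substituent once more: (morpholin-3-yl)methyl in place of 1-acetylpiperidin-4-yl on an amide-type nitrogen. Among the measured compounds shown here, the single measured step concerns a different pair of groups, so it offers only loose guidance; both compound 2 and compound 3 carry a ring-bearing substituent on the amide nitrogen, and no measured step separates two such groups from each other. The expected step of a 1.0-fold lower number from compound 2 to compound 3 (0.02 log units; within the scatter) is therefore none beyond the scatter, and compound 3 is estimated at 30000 nM, within a range from 8000 nM to 120000 nM.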

Compound 3, half-maximal inhibitory concentration: 41700 nM
The estimate for compound 3 lay 1.4-fold (0.14 log units) below the measured number; measured number inside the range.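

With (morpholin-3-yl)methyl in place of 1-acetylpiperidin-4-yl on the amide-type nitrogen, this assay shows a 1.3-fold higher number from compound 2 to compound 3 (0.12 log units; within the scatter), so two substituents that differ in their ring, their hetero atoms and their hydrogen-bond donors read alike at this position. Set against the dimethylamino amide, the morpholine-bearing group gives an at least 2.3-fold lower number from compound 1 to compound 3 (0.37 log units; beyond the scatter), so the lower number seen earlier with 1-acetylpiperidin-4-yl is now seen with a second ring-bearing substituent and does not rest on one group alone. The true size of this step stays open for a single reason: the limit of > 100000 nM in this assay, at which 1 of the 3 values shown sits.

Whether the ring itself matters, or only the larger size of the substituent compared with dimethylamino, remains undecided, and an open-chain group such as a butyl chain or a 2-methoxyethyl group on the amide nitrogen could separate the two. Going by these compounds, it also remains open whether a plain cyclohexyl ring, with no hetero atom, or a substituent ending in a carboxylic acid would move the number beyond the scatter of compound 2 and compound 3.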